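Tail Variation on a Free Fatty Acid Receptor 1 Agonist

The source may hold more compounds than are shown below. What is called first, only, known or untested is meant among the compounds shown, and "the series" means these compounds.

Compound 1 `CC#C[C@@H](Cc1nnn[nH]1)c1ccc(OCc2ccc3scc(-c4ccc(OCCCS(C)(=O)=O)cc4C)c3c2)cc1`: 12 nM
Compound 2 `CC#C[C@@H](Cc1nnn[nH]1)c1ccc(OCc2ccc3scc(-c4ccc(OCCOC)cc4C)c3c2)cc1`: 9 nM

The two measured compounds share one core and differ only in the tail that hangs from an oxygen on an aromatic ring. In a functional assay on cells for agonist activity at Free fatty acid receptor 1 (Homo sapiens), read by FLIPR and calcium flux (a lower number here means that less compound is needed, a higher number that more compound is needed for the effect), compound 1 gives 12 nM, and compound 2 gives 9 nM. Compound 2 carries the lowest of the two numbers, but the step of a 1.3-fold lower number from compound 1 to compound 2 (0.12 log units; within the scatter) lies within the scatter, so the two cannot be told apart on these data.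

Compound 3 `CC#C[C@@H](Cc1nnn[nH]1)c1ccc(OCc2ccc3scc(-c4ccc(OCCC(C)(C)O)cc4C)c3c2)cc1` has not yet been measured. It differs from compound 2 by 1-hydroxy-1-methylethyl in place of methoxy on a saturated chain carbon, two bonds along the chain from an oxygen on an aromatic ring. Within the data shown here, the only step that bears on this change is the one from compound 1 to compound 2, where swapping one tail group for another at the same place left the number essentially unchanged. On that basis the tail at this position seems tolerant of change, though one step is thin evidence. The expectation for compound 3 is therefore a step of a 1.1-fold higher number from compound 2 to compound 3 (0.05 log units; within the scatter), that is, nothing beyond the scatter. Compound 3 is estimated at 10 nM, with a range from 4 nM to 25 nM.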

Compound 3, half-maximal effective concentration: 8 nM
For compound 3 the middle estimate is 1.3-fold (0.10 log units) above the measured one; measured number inside the range.
By their numbers in this assay, from the lowest: compounds 3, 2 and 1 (each within the scatter of the next).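

In this assay, the change from methoxy to 1-hydroxy-1-methylethyl is a 1.1-fold lower number from compound 2 to compound 3 (0.05 log units; within the scatter) and the change from (methylsulfonyl)methyl to the same group is a 1.5-fold lower number from compound 1 to compound 3 (0.18 log units; within the scatter), so all three tails now sit within the scatter of one another. This widens what the first pair showed: going from a tail end of 2 heavy atoms and 0 hydrogen-bond donors to one of 4 heavy atoms and 1 hydrogen-bond donor leaves the number indistinguishable, which makes the tolerance at this place rest on two separate changes rather than one. No supporting measurement is available to explain why the number holds across these tails.

The compounds shown leave open whether this tolerance reaches a tail that ends in an amine or a carboxylic acid, or a much longer chain, where a real step might finally appear. Going by these compounds, all three also share one core, so it remains open whether the same tails would behave alike on a different one.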